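Compound 3 to compound 4: E and Z double bond

The compounds below may be only part of what the source reports. "The series", "measured", "known", "first", "only" and "open" are said of these compounds alone.

In a functional assay on HUVEC cells (Homo sapiens) for inhibition, with a stated time of 4 days (a lower number here means a stronger inhibitor, a higher number a weaker inhibitor), compound 1 `CCc1ccc(OC)c(COc2ccc(Cl)c(C)c2)c1` gives 40000 nM, compound 2 `COC(=O)c1ccc(OC)c(COc2ccc(Cl)c(C)c2)c1` gives 2300 nM, and compound 3 `COc1ccc(C(N)=O)cc1/C=C/c1ccc(Cl)cc1` gives 87 nM, the lowest of the three numbers. Compound 4 `COc1ccc(C(N)=O)cc1/C=C\c1ccc(Cl)cc1` has the same atoms and bonds as compound 3 and differs only in configuration as drawn: the two compounds have the same atoms and bonds and differ only in configuration as drawn: 1 of 1 stereo elements differ; a double bond is drawn E in compound 3 and Z in compound 4. A double bond is drawn E in compound 3 and Z in compound 4.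

Going by the values given here, the only measured step between compounds that differ in one place is a 17-fold lower number from compound 1 to compound 2 (1.24 log units; beyond the scatter). It is large, but it replaces ethyl with methoxycarbonyl and says nothing directly about configuration. No measured E and Z pair exists in this set, so neither the size nor the direction of the coming step is established. Among the compounds with values here, that large step shows only that a single change can move the number well beyond the scatter in this short series. Within the data shown here, with compound 3 at 87 nM, the lowest number so far, a move to a higher number is the more likely outcome, though a lower one cannot be excluded. The expected step is a 4.0-fold higher number from compound 3 to compound 4 (0.60 log units; beyond the scatter), and it remains uncertain. For compound 4 the estimated value is 350 nM, with an expected range of 40 nM to 3000 nM.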

Compound 4, half-maximal inhibitory concentration: 2900 nM
Compound 4: middle estimate off by 8.3-fold (0.92 log units), on the low side; the range from low to high includes it.
By their numbers in this assay, from the lowest: compound 3; then compounds 2 and 4 (each within the scatter of the next); then compound 1.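

In this assay, the double bond configuration in this series is itself a large determinant of the read-out: a 33-fold higher number from compound 3 to compound 4 (1.52 log units; beyond the scatter), with the E form, compound 3, giving the lower number. Going by these compounds alone, earlier, the only step read between compounds differing in one place was an exchange of groups, a 17-fold lower number from compound 1 to compound 2 (1.24 log units; beyond the scatter), so a large change was known only for a replacement of ethyl by methoxycarbonyl, whereas here no atom enters or leaves. The difference between the two numbers can be assigned to the configuration of the double bond alone because no other structural change separates the pair: the fact that compounds 3 and 4 differ only in the configuration as drawn.

As far as these compounds go, this conclusion rests on a single E and Z pair, so it remains open whether the same direction and a similar size of step hold when the amide is replaced by a carboxylic acid or the chloro group by a methoxy group. Also open, from the compounds shown here alone, is how a saturated two-carbon chain in place of the double bond would compare with either compound 3 or compound 4 in this assay.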